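Swapping phenyl for pyridin-3-yl at the assay limit

The source may report more compounds than this note shows. Statements on the series, on what has been measured and on what is new or still open speak of the compounds shown alone.

Compound 1 `COc1ccc(-c2noc(-c3ccccc3)n2)cc1OC1CCCC1`: > 1000000 nM
Compound 2 `COc1ccc(-c2noc(Cc3c[nH]c4ccccc34)n2)cc1OC1CCCC1`: > 1000000 nM

In a functional assay on DU-145 cells (Homo sapiens) for antiproliferative activity, read by MTT assay, with a stated time of 24 h (a higher number here means a weaker inhibitor, a lower number a stronger inhibitor), compound 1 gives > 1000000 nM, which is a limit of the assay and not a number. Compound 2 gives > 1000000 nM, and this too is a limit.

Compound 3 `COc1ccc(-c2noc(-c3cccnc3)n2)cc1OC1CCCC1` has pyridin-3-yl in place of phenyl on an aromatic carbon of the core of compound 1: pyridin-3-yl in place of phenyl on an aromatic carbon. Among the compounds with values here, no two measured compounds differ in just one place, so no measured step sizes this change. The expectation rests only on (the limit of > 1000000 nM in this assay, at which 2 of the 2 values shown sit). In this assay no step beyond the usual scatter is expected, and neither direction is favoured. The estimated step is a number no higher from compound 1 to compound 3 (the limit leaves the size open). For compound 3 the expected value is 1000000 nM, with an estimated range from 200000 nM to 2000000 nM.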

Compound 3, half-maximal inhibitory concentration: > 1000000 nM
Compound 3 gave a limit, no number; the forecaster's own chance of this, stated with the estimate: 75%; the middle value lies on the limit itself.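

Within the data shown here, compound 1 and compound 3 both give only a limit of the assay, not a number, and no step between them can be read. The compounds shown leave open whether pyridin-3-yl in place of phenyl makes any difference in this assay.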